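Ethylamino for methyl beside the amide of compound 1

A few compounds are considered here, and "the series" means these few. Any claim that something is new, unique, unknown or untested is made for them only; others in the source may bear on it.

Measured compounds:
compound 1 `Cc1cc(-c2cccnc2)ccc1C(N)=O`, 22000 nM
compound 2 `Cc1n[nH]c(C)c1-c1cncc(-c2ccc(C(N)=O)c(OC(C)C)c2)c1`, 33 nM

In an assay on cells for inhibition of MAP kinase-interacting serine/threonine-protein kinase 1 (Homo sapiens), read by mobility shift assay, with stated times of 10 min and 60 min, in the presence of a further agent that is not named here (on this read-out higher numbers stand for weaker inhibition and lower numbers for stronger inhibition), compound 1 gives the highest of the two numbers; compound 2 sits far lower, and the gap between them lies beyond the scatter. Compound 3 `CCNc1cc(-c2cccnc2)ccc1C(N)=O` differs from compound 1 by ethylamino in place of methyl on an aromatic carbon, an ethylamino in place of methyl on an aromatic carbon, ortho to the carbamoyl group. Going by the values given here, no measured pair shows this exact change, so the expectation rests on compound 1 alone. The step from compound 1 to compound 3 is expected to be modest, toward stronger inhibition, a 2.8-fold lower number from compound 1 to compound 3 (0.44 log units; beyond the scatter). Compound 3 is therefore estimated at 8000 nM, within 2500 nM to 25000 nM.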

Compound 3, half-maximal inhibitory concentration: 58000 nM
Compound 3: middle estimate off by 7.3-fold (0.86 log units), on the low side, outside the stated range (above it).
By their numbers in this assay, from the lowest: compound 2; then compound 1; then compound 3.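

In this assay, ethylamino in place of methyl on the aromatic carbon ortho to a carbamoyl group gives weaker inhibition (a 2.6-fold higher number from compound 1 to compound 3 (0.42 log units; beyond the scatter)). At this position on the core of compound 1, the change therefore moves inhibition in the weaker direction, although the entering group adds a hydrogen-bond donor and a hydrogen-bond acceptor. Nothing measured here accounts for that direction. The compounds shown leave open whether the nitrogen or the ethyl chain goes with this step, and a plain amine at the same position would separate the two.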